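A few compounds are considered here, and "the series" means these few. Any claim that something is new, unique, unknown or untested is made for them only; others in the source may bear on it.

Of the compounds shown here, three built on one shared core have been tested in a functional assay on HCC827 cells (Homo sapiens) for antiproliferative activity, read by sulforhodamine B assay, with a stated time of 72 h; on this read-out higher numbers stand for weaker inhibition and lower numbers for stronger inhibition. Compound 1 `CN(CCNCc1cn(-c2ccccc2)nn1)CCNc1ccnc2cc(Cl)ccc12` gives 26000 nM. Compound 2 `CN(CCNCc1cn(CC(=O)O)nn1)CCNc1ccnc2cc(Cl)ccc12` reaches only the limit of the assay, > 200000 nM. Compound 3 `CN(CCNCc1cn(CCCO)nn1)CCNc1ccnc2cc(Cl)ccc12` also reaches only the limit, > 200000 nM, so no number is known for it. The two readable steps, an at least 7.6-fold higher number from compound 1 to compound 2 (0.88 log units; beyond the scatter) and an at least 7.6-fold higher number from compound 1 to compound 3 (0.88 log units; beyond the scatter), both replace phenyl with carboxymethyl or 3-hydroxypropyl and both give higher numbers; the step that the two limits leave unreadable from compound 2 to compound 3 cannot be read. Compound 4 `CN(CCNCc1cn(CCCn2nn[nH]c2=O)nn1)CCNc1ccnc2cc(Cl)ccc12` carries a group of 6 heavy atoms (1 carbon, 4 nitrogen, 1 oxygen; one five-membered aromatic ring with 4 hetero atoms) in place of one oxygen atom, on a saturated chain carbon, three bonds along the chain from an aromatic nitrogen. Since compound 2 and compound 3 already sit at the limit of > 200000 nM in this assay, at which 2 of the 3 values shown sit, compound 4 is expected to give 200000 nM, within 60000 nM to 600000 nM. The expected step is a number no higher from compound 3 to compound 4 (the limit leaves the size open), nothing beyond the scatter.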

Compound 4, half-maximal inhibitory concentration: > 200000 nM
Compound 4 was reported as a limit; the forecaster's own chance of this, stated with the estimate: 75%; the middle value sits exactly at the limit.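

Compound 4, with its five-membered aromatic ring with 4 hetero atoms on the chain, also gives a limit and not a number in this assay as well: the limit of > 200000 nM in this assay, at which 3 of the 4 values shown sit. Going by these compounds alone, the steps to compound 4 from compound 2 and from compound 3 cannot be read, and the only readable one is an at least 7.6-fold higher number from compound 1 to compound 4 (0.88 log units; beyond the scatter), which leaves phenyl in compound 1 as the only group here with a number.

As far as these compounds go, whether benzyl or 4-chlorophenyl on this aromatic nitrogen would give a lower number than phenyl stays open. From the compounds shown here alone, how weak compound 2, compound 3 and compound 4 truly are also stays unknown.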